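This account rests on a few compounds, and the source may have more. Where it says the series, first, only, none or still open, it means among the compounds named here.

Of the compounds shown here, three have been measured in a functional assay on the whole organism (strain Sprague-Dawley) for inhibition, with Rattus norvegicus as the target, with a stated time of 10 min; a higher number here means that more compound is needed for the effect, a lower number that less compound is needed. Compound 1 (`O=C(O)c1cnc(-c2ccccc2Cl)[nH]c1=O`) gives 5 mg/kg, compound 2 (`COc1ccc(-c2ncc(C(=O)O)c(=O)[nH]2)c(OC)c1`) gives 5 mg/kg, and compound 3 (`CCOC(=O)c1cnc(-c2ccccc2Cl)[nH]c1=O`) gives 5 mg/kg, so compound 3 stands level with the other two at the digits reported.

Compound 4 (`CCCOc1ccccc1-c1ncc(C(=O)OCC)c(=O)[nH]1`) keeps everything in compound 3 except one group, with propoxy in place of chloro on an aromatic carbon, ortho to a large group: propoxy in place of chloro on an aromatic carbon.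

Among the compounds with values here, only one measured step changes a single place, ethyl in place of hydrogen on an oxygen next to a carbonyl group, and it shows no change at the digits printed from compound 1 to compound 3 (within the scatter). That step lies elsewhere in the molecule, so it bears only indirectly on the new change. Within the data shown here, no measured step replaces chloro, and the data give no direction for this swap. Among the measured compounds shown here, the only further guide is that compound 1 at 5 mg/kg and compound 2 at 5 mg/kg stand level, so no step beyond the scatter is expected in this assay, though with so few compounds the uncertainty stays wide.

The expected outcome is a 1.7-fold lower number from compound 3 to compound 4 (0.22 log units; within the scatter). For compound 4 the estimate is 3 mg/kg, with an expected range from 0.6 mg/kg to 10 mg/kg.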

Compound 4, dose for 50% inhibition: 5 mg/kg
Compound 4: middle estimate off by 1.7-fold (0.22 log units), on the low side, and the stated range covers the measured number.
By their numbers in this assay, from the lowest: compounds 1, 2, 3 and 4 (each within the scatter of the next).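

Replacing chloro with propoxy on an aromatic carbon, ortho to a large group, gives no change at the digits printed from compound 3 to compound 4 (within the scatter) in this assay, although propoxy brings 4 heavy atoms and 1 hydrogen-bond acceptor where chloro had 1 heavy atom and none. Within the data shown here, until now the only single-place step lay elsewhere in the molecule, no change at the digits printed from compound 1 to compound 3 (within the scatter), so this is the first reading at this aromatic carbon, and it shows that this swap of a lone halogen for a larger oxygen-linked chain does not move the dose beyond the scatter. Nothing measured here explains this outcome.

As far as these compounds go, whether the level reading holds for other groups on this carbon, such as an amine, a carboxylic acid or a longer chain like hexyloxy, remains open, as does whether propoxy would read the same with hydrogen in place of ethyl on the oxygen next to the carbonyl group. With all four compounds level in this assay, the compounds shown also do not reveal any change to the shared core that would shift the dose beyond the scatter.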